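This account rests on a few compounds, and the source may have more. Where it says the series, first, only, none or still open, it means among the compounds named here.

Compound 2 `CC(=O)/C=C/c1cc(Cl)ccc1O` gives 60300 nM in a functional assay for inhibition, with Oryctolagus cuniculus as the target (on this read-out lower numbers stand for stronger inhibition and higher numbers for weaker inhibition), the highest of the two numbers measured; compound 1 `CC(=O)/C=C/c1cc(C(C)(C)C)ccc1O` gives 8000 nM, which is a 7.5-fold higher number from compound 1 to compound 2 (0.88 log units; beyond the scatter). Compound 3 `COc1ccc(O)c(/C=C/C(C)=O)c1` differs from compound 2 by methoxy in place of chloro on an aromatic carbon. Going by the values given here, the only measured step, the replacement of tert-butyl by chloro, gave that modest rise and does not involve methoxy, so it bears on the new change only indirectly. Compound 3 is therefore expected to give 30000 nM, within 8000 nM to 100000 nM. The expected step, a 2.0-fold lower number from compound 2 to compound 3 (0.30 log units; within the scatter), is a guess with wide uncertainty rather than a firm prediction.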

Compound 3, half-maximal inhibitory concentration: 3980 nM
The estimate for compound 3 lay 7.5-fold (0.88 log units) above the measured number; the measured number lies below the stated range.
By their numbers in this assay, from the lowest: compounds 3 and 1 (each within the scatter of the next); then compound 2.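

In this assay the position para to a hydroxy group responds to methoxy in place of chloro with a 15-fold lower number from compound 2 to compound 3 (1.18 log units; beyond the scatter) and thus a large step. Methoxy and tert-butyl cannot be told apart here, at a 2.0-fold lower number from compound 1 to compound 3 (0.30 log units; within the scatter) within the scatter, so among these three groups chloro alone stands apart. Nothing at hand gives a reason for this. The compounds shown leave open how an amine, a carboxylic acid or a longer alkoxy chain would read at this position.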